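The source may hold more compounds than are shown below. What is called first, only, known or untested is meant among the compounds shown, and "the series" means these compounds.

Three compounds built on the shared core have been run through an ADME assay on HUVEC cells (Homo sapiens) for cytotoxicity, read by MTT assay, with a stated time of 24 h; a higher number here means a weaker inhibitor, a lower number a stronger inhibitor. Compound 1 `CC1=C([Se]CC(OC(=O)CC[Se]c2ccccc2)C(=O)NCCCCCC(=O)OCc2ccccc2)C(=O)c2ccccc2C1=O` gives 3000 nM in this assay. Compound 2 `CC1=C(SCCC(=O)OC(CC[Se]c2ccccc2)C(=O)NCCCCCC(=O)OCc2ccccc2)C(=O)c2ccccc2C1=O` gives 17000 nM, and compound 3 `CC1=C(SCCC(=O)OC(C[Se]c2ccccc2)C(=O)NC(C)(C)C)C(=O)c2ccccc2C1=O` gives 34000 nM. Compound 1 therefore has the lowest number of the three, making it the strongest inhibitor of cell viability in this small set; the gaps from compound 1 to compound 2 and to compound 3 both lie beyond the usual scatter of repeated measurements, so its place at the bottom is secure.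

The next compound, compound 4 `CC1=C([Se]CC(OC(=O)CNC(=O)OC(C)(C)C)C(=O)NCCCCCC(=O)OCc2ccccc2)C(=O)c2ccccc2C1=O`, is not yet measured. It differs from compound 1 in a single place: a group of 8 heavy atoms (5 carbon, 1 nitrogen, 2 oxygen; no ring) in place of a group of 8 heavy atoms (7 carbon, 1 selenium; one six-membered aromatic ring of carbon only), on a saturated chain carbon bound to a carbonyl carbon. Since no two measured compounds differ by exactly this exchange, there is no measured step to lean on, only the numbers of the three compounds shown.

The expectation is a moderate step toward a weaker inhibitor, that is a higher number, of about a 2.7-fold higher number from compound 1 to compound 4 (0.43 log units; beyond the scatter) from compound 1 to compound 4, a shift that is more than the scatter but not a large one. Compound 4 is accordingly expected to give around 8000 nM in this assay, with a likely range from 2500 nM to 25000 nM.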

Compound 4, half-maximal inhibitory concentration: 36000 nM
For compound 4 the middle estimate is 4.5-fold (0.65 log units) below the measured one; the measured number lies above the stated range.
By their numbers in this assay, from the lowest: compound 1; then compounds 2, 3 and 4 (each within the scatter of the next, the first and the last beyond it).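

In this assay, replacing the selenium-bearing aromatic group of compound 1 with (tert-butoxycarbonyl)amino, on a saturated chain carbon bound to a carbonyl carbon, gives a 12-fold higher number from compound 1 to compound 4 (1.08 log units; beyond the scatter). Within the data shown here, this is the first comparison in the set in which only one place changes, and it shows that the number is sensitive to what sits at this position, even though the two groups have the same count of heavy atoms. No measurement shown here offers any explanation of the size of this step.

The exchange changes several things at once: it removes a selenium atom and an aromatic ring, and it brings in a carbamate with an added hydrogen-bond donor, so the compounds shown leave open which of these changes matters for the read-out. A phenylthio group on the same chain, with sulfur in place of selenium, would test the selenium alone, while a plain benzyl group would test the aromatic ring without either atom, and a free amine in place of the (tert-butoxycarbonyl)amino group would show whether the bulk of that protecting group counts.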